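Estimating Compound 4 From a Limit at Compound 3

A few compounds are considered here, and "the series" means these few. Any claim that something is new, unique, unknown or untested is made for them only; others in the source may bear on it.

Three measured compounds share one core and differ only in the aryl group on an aromatic nitrogen. Compound 1 `CCOC(=O)C1=C(C)N/C(=C/c2cc(C)n(-c3ccc(CN(C)C)cc3)c2C)C1=O` gives 12.5 ug/mL in a physicochemical assay for solubility, read by nephelometry, in phosphate buffer, measured as kinetic solubility, at pH 6.5; a lower number here means a less soluble compound, a higher number a more soluble compound. Compound 2 `CCOC(=O)C1=C(C)N/C(=C/c2cc(C)n(-c3cccc(C(F)(F)F)c3)c2C)C1=O` gives 2.1 ug/mL in this assay. Compound 3 `CCOC(=O)C1=C(C)N/C(=C/c2cc(C)n(-c3ccc(N(C)C)cc3)c2C)C1=O` sits at the limit of < 1.6 ug/mL in this assay, at which 1 of the 3 values shown sits. In this assay compound 3 gives < 1.6 ug/mL, which is a limit of the assay and not a number. Among the steps, a 6.0-fold lower number from compound 1 to compound 2 (0.77 log units; beyond the scatter) and an at least 7.8-fold lower number from compound 1 to compound 3 (0.89 log units; beyond the scatter) both lower the number, while an at least 1.3-fold lower number from compound 2 to compound 3 (0.11 log units; that floor lies within the scatter) is only a bound whose floor lies within the scatter. Compound 4 `CCOC(=O)C1=C(C)N/C(=C/c2cc(C)n(-c3ccncc3)c2C)C1=O` carries pyridin-4-yl in place of 4-(dimethylamino)phenyl on an aromatic nitrogen. Going by the values given here, no measured step swaps the aryl group for pyridin-4-yl, so the bearing of the three steps is indirect: they show that the aryl group on this nitrogen moves the number by modest amounts, and compound 3 starts at the floor, so only a rise or no change can be seen. The account expects a modest rise, an at least 3.1-fold higher number from compound 3 to compound 4 (0.49 log units; beyond the scatter), and estimates compound 4 at 5 ug/mL, within a range from 1.5 ug/mL to 20 ug/mL.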

Compound 4, solubility: 50 ug/mL
Beside the measured number, compound 4's estimate is 10-fold (1.00 log units) below it; measured number outside the range, above it.
By their numbers in this assay, from the lowest: compound 2; then compound 1; then compound 4. At a limit, below all of these: compound 3.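

Going by these compounds alone, on the aromatic nitrogen, pyridin-4-yl is the first aryl group of this set to rise above compound 1 in this assay, giving a 4.0-fold higher number from compound 1 to compound 4 (0.60 log units; beyond the scatter) and so placing the top of the series with this group rather than with the (dimethylamino)methyl-bearing ring. The change is larger against the other two aryl groups, with a 24-fold higher number from compound 2 to compound 4 (1.38 log units; beyond the scatter) and an at least 31-fold higher number from compound 3 to compound 4 (1.49 log units; beyond the scatter) as the two steps. The second of these is only a floor, as compound 3 stands at a limit of the assay and not at a number: (the limit of < 1.6 ug/mL in this assay, at which 1 of the 4 values shown sits).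

The compounds shown leave open whether the rise depends on where the ring nitrogen sits, as they include neither pyridin-3-yl nor pyridin-2-yl, and they hold no plain phenyl for comparison. They also leave open what a (dimethylamino)methyl group or a carboxylic acid on the pyridine ring would do.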